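Aryl replacement on the piperazine of compound 1

The source may report more compounds than this note shows. Statements on the series, on what has been measured and on what is new or still open speak of the compounds shown alone.

Compound 1 `CSc1ccccc1N1CCN(CCCCn2ncc(=O)n(C)c2=O)CC1` stands lowest of the three numbers seen in an assay for displacement of a labelled ligand from Adrenergic receptor alpha-1 (Homo sapiens) (on this read-out higher numbers stand for weaker inhibition and lower numbers for stronger inhibition), where compound 1 gives 1.8 nM. Compound 2 `COc1ccc(N2CCN(CCCCn3ncc(=O)n(C)c3=O)CC2)c(C#N)c1` gives 380 nM in this assay, and compound 3 `Cn1c(=O)cnn(CCCCN2CCN(c3c(Br)cccc3C#N)CC2)c1=O` gives 450 nM. Exchanging the aryl on the ring nitrogen has so far moved the number a 250-fold higher number from compound 1 to compound 3 (2.40 log units; beyond the scatter). Compound 4 `Cn1c(=O)cnn(CCCCN2CCN(c3cccc(O)c3)CC2)c1=O` differs from compound 1 at the same position: 3-hydroxyphenyl in place of 2-(methylsulfanyl)phenyl on an amine nitrogen in a ring. Among the compounds with values here, only the step to compound 3 bears directly on this exchange, and it was large and unfavourable, with compound 2 pointing the same way. The expected step is therefore a clearly higher number, though its size is uncertain, estimated as a 56-fold higher number from compound 1 to compound 4 (1.74 log units; beyond the scatter). For compound 4 the expected value in this assay is 100 nM, within a range of 15 nM to 600 nM.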

Compound 4, inhibition constant: > 10000 nM
Compound 4: no number, only a limit (the forecaster's own chance of this, stated with the estimate: 2%); at least 100-fold (2.00 log units) between middle value and limit.
By their numbers in this assay, from the lowest: compound 1; then compounds 2 and 3 (each within the scatter of the next). At a limit, above all of these: compound 4.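

Compound 4 carries no number, only a limit of this assay: the limit of > 10000 nM in this assay, at which 1 of the 4 values shown sits. Exchanging the aryl group on the ring nitrogen for 3-hydroxyphenyl gives an at least 5500-fold higher number from compound 1 to compound 4 (3.74 log units; beyond the scatter), and also an at least 22-fold higher number from compound 3 to compound 4 (1.34 log units; beyond the scatter). Going by these compounds, this position can therefore move the read-out further than compound 3 showed, and the full size of the step remains unknown.

The compounds shown leave open whether the hydroxyl group or its ring location accounts for this step. A 2-hydroxyphenyl or a 3-(methylsulfanyl)phenyl on the same nitrogen would separate the two.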